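The compounds below may be only part of what the source reports. "The series", "measured", "known", "first", "only" and "open" are said of these compounds alone.

Measured so far in an ADME assay on Vero cells (Chlorocebus sabaeus) for cytotoxicity, read by CellTiter-Glo, with a stated time of 72 h; a lower number here means that less compound is tolerated, a higher number that more compound is tolerated:
Compound 1 `COCC(C)Nc1n[n+]([O-])c2ccccc2[n+]1[O-]`: > 50 ug/mL (a limit)
Compound 2 `[O-][n+]1nc(NC2CCC2)[n+]([O-])c2ccc(F)cc21`: 1.6 ug/mL

Compound 1 reads > 50 ug/mL, which is a limit and not a number.

Going by the values given here, compound 2, at 1.6 ug/mL, therefore holds the only actual number in this assay. Among the compounds with values here, no step between the two measured compounds is available, so the effect of any single change has not been measured.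

Compound 3 `COCC(C)Nc1n[n+]([O-])c2cc(F)ccc2[n+]1[O-]` keeps the core of compound 2 and has 1-(methoxymethyl)ethyl in place of cyclobutyl on a nitrogen on an aromatic ring. The same cut, one bond further out, reads cyclobutylamino to (1-(methoxymethyl)ethyl)amino.

Within the data shown here, the entering group is also carried by compound 1, whose limit of > 50 ug/mL is the only guide to it.

On that basis a rise beyond the scatter is expected in this assay, with more compound tolerated, and the expected step is a 6.9-fold higher number from compound 2 to compound 3 (0.84 log units; beyond the scatter).

The estimated value expected for compound 3 is 11 ug/mL, with a range of 3 ug/mL to 40 ug/mL.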

Compound 3, half-maximal cytotoxic concentration: 6.3 ug/mL
For compound 3 the middle estimate is 1.7-fold (0.24 log units) above the measured one, within the range that was stated.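

In this assay, 1-(methoxymethyl)ethyl in place of cyclobutyl on a nitrogen on an aromatic ring gives a 3.9-fold higher number from compound 2 to compound 3 (0.60 log units; beyond the scatter), the first measured effect of a single change at this place, with the fluoro group present on both sides of the comparison. The fluoro group now has a step of its own: with the 1-(methoxymethyl)ethyl group kept, fluoro in place of hydrogen on an aromatic carbon gives an at least 7.9-fold lower number from compound 1 to compound 3 (0.89 log units; beyond the scatter), so in this series the two single changes move the number in opposite directions, each beyond the scatter. The second step gives only a bound, and its true size stays unknown, because compound 1 carries a limit and not a number: the limit of > 50 ug/mL in this assay, at which 1 of the 3 values shown sits.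

The compounds shown leave open whether the step at the nitrogen follows from opening the ring or from the oxygen of the entering group, a question that an open-chain sec-butyl group or a tetrahydrofuranyl group at that nitrogen would help to separate. They also leave open whether the drop seen with fluoro is particular to that atom, since chloro or methoxy on the same aromatic carbon would test this.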